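The compounds below may be only part of what the source reports. "The series", "measured", "known", "first", "only" and "open" are said of these compounds alone.

The study compares three ureas built on a shared core, tested in an ADME assay on Raji cells (Homo sapiens) for cytotoxicity, with a stated time of 72 h; a lower number here means that less compound is needed, a higher number that more compound is needed for the effect. Compound 1 `COc1ccc(NC(=O)Nc2cc(C)nc3ccccc23)cc1` carries a methoxy group; in this assay compound 1 reaches only a limit of the assay, > 25000 nM. Compound 2 `Cc1cc(NC(=O)Nc2ccc(N)cc2)c2ccccc2n1` has amino in place of methoxy on an aromatic carbon; in this assay compound 2 likewise sits at a limit, > 25000 nM. Compound 3 `Cc1cc(NC(=O)Nc2ccc(C(N)=O)cc2)c2ccccc2n1` bears carbamoyl in place of methoxy on an aromatic carbon; in this assay compound 3 again gives only a limit, > 25000 nM. Because of this, the steps a step that the two limits leave unreadable from compound 1 to compound 2, a step that the two limits leave unreadable from compound 1 to compound 3 and a step that the two limits leave unreadable from compound 2 to compound 3 cannot be read for size, since the limit of > 25000 nM in this assay, at which 3 of the 3 values shown sit, is where every value stands. Compound 3 therefore cannot be placed relative to compound 1 or compound 2 beyond sharing that limit.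

The next compound, compound 4 `Cc1cc(NC(=O)Nc2ccc(C(F)(F)F)cc2)c2ccccc2n1`, differs from compound 3 by trifluoromethyl in place of carbamoyl on an aromatic carbon. Among the measured compounds shown here, no measured step bears on this exchange, and none of the measured steps gives a readable size in this assay, so nothing in these data points to a change beyond the scatter. Compound 4 is expected to sit near the same limit, with the step that the limit leaves unreadable from compound 3 to compound 4 estimated to be small. The estimate for compound 4 in this assay is 30000 nM, within a range from 8000 nM to 100000 nM.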

Compound 4, half-maximal effective concentration: 23000 nM
Compound 4: the middle estimate sits 1.3-fold (0.12 log units) above what was measured, within the range that was stated.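

Trifluoromethyl, para to a large group, is the first group at this position to give a number rather than a limit in this assay, so the exchange now has a floor on its size, with an at least 1.0-fold lower number from compound 3 to compound 4 (0.03 log units; that floor lies within the scatter), an at least 1.0-fold lower number from compound 2 to compound 4 (0.03 log units; that floor lies within the scatter) and an at least 1.0-fold lower number from compound 1 to compound 4 (0.03 log units; that floor lies within the scatter). All of these floors lie within the scatter, so the data do not show that trifluoromethyl changes the result, though they do not exclude a larger step in that direction. Among the compounds shown here, the other compounds remain unresolved, and the earlier steps among them still cannot be read: the limit of > 25000 nM in this assay, at which 3 of the 4 values shown sit.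

On these data alone, how far compound 1, compound 2 and compound 3 really lie from compound 4 stays open, since only compound 4 has a number. Also open, as far as these compounds go, is whether a chlorine atom, a nitrile or a carboxylic acid at this position would give a number rather than a limit in this assay, and whether a change elsewhere on the shared core would do so.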